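This account rests on a few compounds, and the source may have more. Where it says the series, first, only, none or still open, it means among the compounds named here.

Measured in an ADME assay on L1210 cells (Mus musculus) for cytotoxicity, with a stated time of 48 h; a lower number here means a stronger inhibitor, a higher number a weaker inhibitor:
- compound 1 `CC1=CCC[C@](C)(CC/C(C)=C/CC2=C(O)C(=O)C=C(N[C@@H](C(=O)O)C(C)C)C2=O)[C@@H]1C`: 3 ug/mL
- compound 2 `C=C1[C@H](C)CCC[C@]1(C)CC/C(C)=C/CC1=C(O)C(=O)C=C(NCC(=O)O)C1=O`: 4 ug/mL
- compound 3 `CC1=CCC[C@](C)(CC/C(C)=C/CC2=C(O)C(=O)C=C(N[C@H](C(=O)O)[C@H](C)O)C2=O)[C@@H]1C`: > 10 ug/mL

Compound 3 gives > 10 ug/mL, which is a limit of the assay and not a number. Among the compounds with values here, it therefore has no exact place on the scale, and it is the only one of the three values of this kind.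

Compound 4 `CC1=CCC[C@](C)(CC/C(C)=C/CC2=C(O)C(=O)C=C(NCC(=O)O)C2=O)[C@@H]1C` follows from compound 3 by one change: hydrogen in place of 1-hydroxyethyl on a saturated chain carbon bound to an amine nitrogen and a carbonyl carbon. Put another way, 1-carboxy-2-hydroxypropyl gives way to carboxymethyl.

Within the data shown here, one measured step bears directly on this change: an at least 3.3-fold higher number from compound 1 to compound 3 (0.52 log units; beyond the scatter). That step ends at the same 1-carboxy-2-hydroxypropyl group that now leaves, and it lies beyond the scatter. It gives a size only as a bound, so the new step is expected to go towards a lower number in this assay, by a modest amount or more.

The carboxymethyl group already appears in compound 2, which gives 4 ug/mL, so that value is the best guide to where compound 4 should land. The remaining difference between the two structures has not been tested on its own, which keeps the range wide.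

The expected change is an at least 2.5-fold lower number from compound 3 to compound 4 (0.39 log units; beyond the scatter).

Compound 4 is estimated at 4 ug/mL, with an expected range of 1.8 ug/mL to 9 ug/mL.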

Compound 4, half-maximal inhibitory concentration: 3.5 ug/mL
For compound 4 the middle estimate is 1.1-fold (0.06 log units) above the measured one; the range from low to high includes it.
By their numbers in this assay, from the lowest: compounds 1, 4 and 2 (each within the scatter of the next). At a limit, above all of these: compound 3.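

In this assay, taking 1-hydroxyethyl off the saturated chain carbon bound to an amine nitrogen and a carbonyl carbon gives an at least 2.8-fold lower number from compound 3 to compound 4 (0.45 log units; beyond the scatter), so the change from 1-carboxy-2-hydroxypropyl to carboxymethyl undoes the loss seen with that group on the amine nitrogen. Compound 3 gives > 10 ug/mL, a limit of the assay and not a number, so this step has a size only as a bound: the limit of > 10 ug/mL in this assay, at which 1 of the 4 values shown sits. On this carbon, hydrogen and isopropyl are not told apart, with a 1.2-fold higher number from compound 1 to compound 4 (0.07 log units; within the scatter), and exchanging one ring-bearing carbon group for the other, with carboxymethyl kept in place, gives a 1.1-fold lower number from compound 2 to compound 4 (0.06 log units; within the scatter), which leaves 1-hydroxyethyl as the only group shown here that stands apart from the rest.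

From the compounds shown here alone, whether a longer chain, an amine or a benzyl group on this carbon would fall with hydrogen and isopropyl or with 1-hydroxyethyl remains open. The role of the carboxylic acid also remains open, as every compound shown carries one, so a methyl ester or an amide in its place could not be judged from these values.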